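Swapping a ring for a methyl on a urotensin antagonist

This account rests on a few compounds, and the source may have more. Where it says the series, first, only, none or still open, it means among the compounds named here.

Of the compounds shown here, three have been tested in a functional assay on RMS13 cells for antagonist activity at Urotensin-2 receptor (Homo sapiens), read by FLIPR and calcium flux, with a stated time of 1 h; on this read-out higher numbers stand for weaker inhibition and lower numbers for stronger inhibition. Compound 1 `CCN1CCN(c2cccc3c2C(=O)N([C@H](CCCNS(=O)(=O)c2cn(C)c(C)n2)c2ccc(OC)c(OC)c2)C3=O)CC1` gives 810 nM in this assay. Compound 2 `CCN1CCN(c2cccc3c2CN([C@H](CCCNC(=O)c2c(C)n[nH]c2C)c2ccc(OC)c(OC)c2)C3=O)CC1` gives 130 nM in this assay. Compound 3 `COc1ccc([C@@H](CCCN(C)S(=O)(=O)c2cccs2)N2Cc3c(cccc3N3CCN(C4CCC4)CC3)C2=O)cc1OC` gives 510 nM in this assay. Among these three numbers compound 3 stands second highest: its number and that of compound 1 lie within the usual scatter of each other, so no difference between the two can be claimed, while compound 2 has a clearly lower number, which means stronger inhibition than compound 3.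

Compound 4 `COc1ccc([C@@H](CCCN(C)S(=O)(=O)c2cccs2)N2Cc3c(cccc3N3CCN(C)CC3)C2=O)cc1OC` has not yet been measured in this assay. It differs from compound 3 in one place: methyl in place of cyclobutyl on an amine nitrogen in a ring. Among the compounds with values here, no pair of measured compounds shows what such a change does here, so there is no measured step to lean on.

Without a comparable measured step, the expectation for compound 4 rests on the small size of the alteration, and the estimated step from compound 3 to compound 4 in this assay is a 1.4-fold higher number from compound 3 to compound 4 (0.14 log units; within the scatter), a shift not clearly beyond the scatter. On that basis compound 4 is expected to give about 700 nM in this assay, with a likely range from 250 nM to 2000 nM.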

Compound 4, half-maximal inhibitory concentration: 340 nM
For compound 4 the middle estimate is 2.1-fold (0.31 log units) above the measured one; the measured number falls inside the stated range.
By their numbers in this assay, from the lowest: compound 2; then compounds 4, 3 and 1 (each within the scatter of the next, the first and the last beyond it).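

Replacing the 4-cyclobutylpiperazin-1-yl with 4-methylpiperazin-1-yl takes away the four-membered carbon ring and leaves 1 heavy atom on this amine nitrogen where there were 4, yet in this assay the step is a 1.5-fold lower number from compound 3 to compound 4 (0.18 log units; within the scatter), so the two compounds cannot be told apart. Within the data shown here, this pair gives the first direct reading at this position, and it shows that, with the rest of compound 3 held fixed, the cyclobutyl ring can be swapped for a methyl without a change that rises above the noise of the measurement. Nothing measured here speaks to why the two compounds read alike.

What the compounds shown leave open is how far this tolerance reaches: a bare hydrogen on the same nitrogen, an acetyl group, a benzyl group or a longer alkyl chain could each give a different answer. It is also an open question whether the same swap would read the same way on a compound with a different side chain, since this single pair speaks only for the side chain that compound 3 and compound 4 share.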